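This account rests on a few compounds, and the source may have more. Where it says the series, first, only, none or still open, it means among the compounds named here.

In a functional assay on BaF3 cells (Mus musculus) for antiproliferative activity, with a stated time of 48 h (on this read-out higher numbers stand for weaker inhibition and lower numbers for stronger inhibition), compound 2 `CC(=O)N1CCN([C@H]2C[C@@H](n3cc(-c4ccc(O)cc4)c4c(N)ncnc43)C2)CC1` gives > 10000 nM, which is a limit of the assay and not a number. Its true value is therefore unknown, and no exact size can be given for any step that starts from it. Compound 3 `CC(=O)N1CCN([C@H]2C[C@@H](n3cc(-c4cccc(O)c4)c4c(N)ncnc43)C2)CC1` keeps the shared core and changes only the aryl group: 3-hydroxyphenyl in place of 4-hydroxyphenyl on an aromatic carbon.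

Going by the values given here, one measured step bears on this change. Compound 1 `CC(=O)N1CCN([C@H]2C[C@@H](n3cc(-c4ccc(Cl)c(O)c4)c4c(N)ncnc43)C2)CC1` gives 3700 nM and carries a 4-chloro-3-hydroxyphenyl group. The step of an at least 2.7-fold higher number from compound 1 to compound 2 (0.43 log units; beyond the scatter) exchanges that group for 4-hydroxyphenyl and is modest but beyond the scatter. The 3-hydroxyphenyl of compound 3 resembles the group of compound 1 but has no chloro, so it may recover part of that step, though probably not all of it. This single comparison is thin support, and the reading may well stay at the limit. The expected change is small and toward a lower number, written as an at least 1.2-fold lower number from compound 2 to compound 3 (0.09 log units; that floor lies within the scatter). Compound 3 is estimated at 8000 nM, with an expected range from 3500 nM to 20000 nM.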

Compound 3, half-maximal inhibitory concentration: > 10000 nM
Compound 3: a limit, no number (the forecaster's own chance of this, stated with the estimate: 50%); middle value at least 1.2-fold (0.09 log units) away from the limit.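

In this assay compound 3 gives > 10000 nM as a limit of the assay and not a number. The step between compound 2 and compound 3 cannot be read because both ends are limits, so no size can be given for the change from 4-hydroxyphenyl to 3-hydroxyphenyl on this aromatic carbon: the limit of > 10000 nM in this assay, at which 2 of the 3 values shown sit. What is new is a cleaner comparison with compound 1, whose earlier step to compound 2 changed both the chloro and the place of the hydroxyl group: hydrogen in place of chloro alone gives an at least 2.7-fold higher number from compound 1 to compound 3 (0.43 log units; beyond the scatter) and so shows that, with the 3-hydroxyphenyl pattern kept, removing the chloro by itself is enough to take the reading to the limit.

The compounds shown leave open which of 3-hydroxyphenyl and 4-hydroxyphenyl gives the stronger inhibition, as neither has a number here. They also leave open whether the chloro needs the hydroxyl group at all, as a plain 4-chlorophenyl would test, and whether a fluoro or a methyl in the place of the chloro would give a readable value.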